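This account rests on a few compounds, and the source may have more. Where it says the series, first, only, none or still open, it means among the compounds named here.

Compound 1 `N=c1oc2ccccc2cc1C(=O)N/N=C1\C(=O)Nc2ccc(S(=O)(=O)N3CCOCC3)cc21` gives 132000 nM
Compound 2 `Cc1ccc(/N=C2\C(=O)Nc3ccc(S(=O)(=O)N4CCOCC4)cc32)cc1` gives 309000 nM
Compound 3 `Cc1ccc(S(=O)(=O)N/N=C2\C(=O)Nc3ccc(S(=O)(=O)N4CCOCC4)cc32)cc1` gives 261000 nM

All three numbers come from an ADME assay on WI-38 cells (Homo sapiens) for cytotoxicity, read by sulforhodamine B assay, with a stated time of 24 h (a higher number here means a weaker inhibitor, a lower number a stronger inhibitor), and belong to compounds that share part of their core. Compound 3 at 261000 nM lies within the usual scatter of both compound 2 and compound 1, so its place among the three is not firmly settled.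

Compound 4 `CC(=O)N/N=C1\C(=O)Nc2ccc(S(=O)(=O)N3CCOCC3)cc21` has not been measured yet. Set against compound 3, compound 4 carries acetyl in place of (4-methylphenyl)sulfonyl on an amine nitrogen and is otherwise the same.

Within the data shown here, no measured pair differs in just one place, so nothing shows directly what such an exchange does. Among the measured compounds shown here, the only guide is how the values spread: with quite different groups on the core, compound 1 reads 132000 nM and compound 2 reads 309000 nM in this assay here. On that basis, no step beyond the scatter is expected. The estimate is a 1.3-fold lower number from compound 3 to compound 4 (0.12 log units; within the scatter) and would stay inside that scatter. For compound 4 the estimated value is 200000 nM with an expected range from 90000 nM to 400000 nM as the likely span.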

Compound 4, half-maximal inhibitory concentration: 325000 nM
Compound 4: middle estimate off by 1.6-fold (0.21 log units), on the low side, and the stated range covers the measured number.
By their numbers in this assay, from the lowest: compounds 1, 3, 2 and 4 (each within the scatter of the next, the first and the last beyond it).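

In this assay, acetyl in place of (4-methylphenyl)sulfonyl on an amine nitrogen gives a 1.2-fold higher number from compound 3 to compound 4 (0.10 log units; within the scatter), so this first exchange at a single place stays within the scatter, even though a six-membered aromatic ring leaves with the group. Acetamido in place of 4-methylphenyl on a double-bonded nitrogen gives a 1.1-fold higher number from compound 2 to compound 4 (0.02 log units; within the scatter), again within the scatter, while one carbon atom in place of the group of 11 heavy atoms on a carbonyl carbon, which takes away two six-membered aromatic rings, gives a 2.5-fold higher number from compound 1 to compound 4 (0.39 log units; beyond the scatter), a modest step and the only one of the three beyond the scatter. No measurement at hand accounts for any of these steps.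

As far as these compounds go, it remains open whether a longer carbon chain or a carboxylic acid in place of acetyl would also stay within the scatter, or would shift the number as far as the group in compound 1 does. The compounds shown also cannot tell whether that step depends on the whole two-ring group of compound 1 or only on some part of it.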